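Replacing the ethoxycarbonyl end of compound 3 with hydroxy

A few compounds are considered here, and "the series" means these few. Any claim that something is new, unique, unknown or untested is made for them only; others in the source may bear on it.

Measured in an ADME assay on L929 cells (Mus musculus) for cytotoxicity, read by resazurin assay, with a stated time of 48 h; on this read-out lower numbers stand for higher toxicity in this test and higher numbers for lower toxicity in this test:
- Compound 1 (`O=[N+]([O-])c1ccc2nn(Cc3ccccc3)c(OCCCBr)c2c1`) gives 59000 nM
- Compound 2 (`COC(=O)COc1c2cc([N+](=O)[O-])ccc2nn1Cc1ccccc1`) gives > 256000 nM, a limit of the assay
- Compound 3 (`CCOC(=O)CCCOc1c2cc([N+](=O)[O-])ccc2nn1Cc1ccccc1`) gives > 256000 nM, a limit of the assay

Compound 3 stands at the limit of > 256000 nM in this assay, at which 2 of the 3 values shown sit, so its true value is not known. Compound 4 (`O=[N+]([O-])c1ccc2nn(Cc3ccccc3)c(OCCO)c2c1`) carries hydroxy in place of (ethoxycarbonyl)methyl on a saturated chain carbon, two bonds along the chain from an oxygen on an aromatic ring.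

Among the compounds with values here, two measured steps bear on this: an at least 4.3-fold higher number from compound 1 to compound 2 (0.63 log units; beyond the scatter) and an at least 4.3-fold higher number from compound 1 to compound 3 (0.63 log units; beyond the scatter). Both lose the bromo end, but neither puts hydroxy on the chain. Within the data shown here, compound 4 also has no bromo, so with an at least 4.3-fold higher number from compound 1 to compound 3 (0.63 log units; beyond the scatter) as the guide, little or no step toward lower numbers is expected in this assay. The estimated move is an at least 1.1-fold lower number from compound 3 to compound 4 (0.04 log units; that floor lies within the scatter) here. The expected value of compound 4 is 230000 nM within an estimated range from 100000 nM to 400000 nM in this test.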

Compound 4, concentration lethal to 50% of the cells: > 256000 nM
Compound 4 ended at the assay's limit; the forecaster's own chance of this, stated with the estimate: 55%; at least 1.1-fold (0.04 log units) between middle value and limit.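

In this assay compound 4 gives > 256000 nM, a limit of the assay. Hydroxy in place of bromomethyl on the chain gives an at least 4.3-fold higher number from compound 1 to compound 4 (0.63 log units; beyond the scatter), so a chain end with a hydrogen-bond donor joins the two ester ends, and only the bromo end of compound 1 gives a measurable value. The steps linking compound 4 to compound 2 and compound 3 cannot be read: the limit of > 256000 nM in this assay, at which 3 of the 4 values shown sit.

From the compounds shown here alone, how far these three compounds lie beyond the limit stays unknown. Also open, going by these compounds, is whether an amine or a carboxylic acid at the chain end would stay at this limit or give a lower number, as the bromo end does.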